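Phenyl for cyclopropyl on the shared core

The source may hold more compounds than are shown below. What is called first, only, known or untested is meant among the compounds shown, and "the series" means these compounds.

Compound 3 `CCCc1nc(C)c2c(C3CC3)nnc(O)n12` gives > 48000 nM in a functional assay for inhibition, with Homo sapiens as the target (a higher number here means a weaker inhibitor, a lower number a stronger inhibitor), a limit of the assay rather than a number. Compound 1 `C=CCn1ncc2cnc(C)n2c1=O` gives > 48000 nM in this assay, also a limit. Compound 2 `CCCc1nc(C)c2c(C(C)C)cnc(Nc3cc[nH]n3)n12` gives > 48000 nM, again a limit. Going by the values given here, the whole set therefore shows (the limit of > 48000 nM in this assay, at which 3 of the 3 values shown sit), and no step between two measured compounds can be stated, since none of the three values is a number.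

Compound 4 `CCCc1nc(C)c2c(-c3ccccc3)nnc(O)n12` differs from compound 3 by phenyl in place of cyclopropyl on an aromatic carbon. With every measured value a limit, the series offers no direction and no size for this change, so the working assumption is that compound 4 stays at the limit as well, with no step beyond the scatter visible. The expected step is a step that the limit leaves unreadable from compound 3 to compound 4. Compound 4 is estimated at 60000 nM. The expected range for compound 4 is estimated to run from 8000 nM to 300000 nM, with a reported limit rather than a number the more likely outcome.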

Compound 4, half-maximal inhibitory concentration: > 48000 nM
Compound 4: only a limit was reported; the forecaster's own chance of this, stated with the estimate: 75%; the middle value is on the limit's open side.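

In this assay compound 4 gives > 48000 nM, a limit and not a number. Going by these compounds alone, no step can therefore be read between compound 3 and compound 4. The compounds shown leave open how phenyl and cyclopropyl compare, and which change on the shared core would give a measurable value.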